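The source may hold more compounds than are shown below. What is called first, only, known or untested is meant among the compounds shown, and "the series" means these compounds.

Measured so far:
Compound 1 `COc1ccc(-c2nc3ccccn3c2/C=C/C(=O)c2cc(OC)c(OC)c(OC)c2)cc1` gives 4800 nM in a functional assay on HT-29 cells (Homo sapiens) for inhibition, read by sulforhodamine B assay, with a stated time of 48 h; on this read-out higher numbers stand for weaker inhibition of growth and lower numbers for stronger inhibition of growth.
Compound 2 `COc1cc(C(=O)/C=C/c2c(-c3ccc(F)cc3)nc3ncccn23)cc(OC)c1OC` gives 2520 nM in this assay.

Compound 2 has the lowest of the two numbers, but its gap to compound 1 lies within the scatter of repeated measurements, so the two cannot be told apart on these data. The two compounds also differ in two places, in the core as well as in the group on the phenyl ring, so no single step can be read from their values.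

Compound 3 `COc1ccc(-c2nc3ncccn3c2/C=C/C(=O)c2cc(OC)c(OC)c(OC)c2)cc1` has not yet been measured. It keeps the core of compound 2 and changes only one thing: methoxy in place of fluoro on an aromatic carbon. This is the same group that compound 1 carries on its phenyl ring, on a different core.

Without a clean comparison, the expectation rests on the fact that compound 1, which carries methoxy, gives 4800 nM, a number close to that of compound 2. The step from compound 2 to compound 3 is therefore expected to be small, a 1.4-fold higher number from compound 2 to compound 3 (0.14 log units; within the scatter), and not beyond the scatter in either direction. Compound 3 is estimated to give 3500 nM, with a likely range from 1200 nM to 10000 nM.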

Compound 3, concentration for 50% growth inhibition: 2190 nM
Compound 3: middle estimate off by 1.6-fold (0.20 log units), on the high side; measured number inside the range.
By their numbers in this assay, from the lowest: compounds 3, 2 and 1 (each within the scatter of the next, the first and the last beyond it).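

In this assay, among the compounds shown here, the change from 4-fluorophenyl to 4-methoxyphenyl on the shared core gives the first clean comparison at this position, and the step is a 1.2-fold lower number from compound 2 to compound 3 (0.06 log units; within the scatter). With the rest of the molecule held the same, this read-out therefore cannot tell the two groups apart on this ring, even though methoxy is the larger group and brings a hydrogen-bond acceptor that fluoro does not have. Nothing measured here offers an explanation, so this stands as an observation only.

It remains open whether a different kind of group in the same place, such as an amine, a carboxylic acid or a longer chain, would shift the number beyond the scatter, since fluoro and methoxy are the only two groups shown there. It also remains open whether this change would give a similarly small step on the core of compound 1, for which only the methoxy form is shown.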